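From Iodo to Isopropyl: Expected Tolerability of Compound 4

The source may hold more compounds than are shown below. What is called first, only, known or untested is meant among the compounds shown, and "the series" means these compounds.

Measured so far in an ADME assay on TZM cells (Homo sapiens) for cytotoxicity; a higher number here means that more compound is tolerated, a lower number that less compound is tolerated:
Compound 1 `COc1ccc(Cc2cc(OC3CCCCC3C)c(C(C)C)c(=O)[nH]2)cc1` gives 132000 nM.
Compound 2 `CC(C)c1c(OC2CCCCC2C)cc(Cc2ccc(F)cc2)[nH]c1=O` gives 74500 nM.
Compound 3 `CC1CCCCC1Oc1cc(CCc2ccccc2)[nH]c(=O)c1I` gives only a limit of the assay, > 300000 nM.

Compound 3 thus stands apart from the other two: it sits at the limit of > 300000 nM in this assay, at which 1 of the 3 values shown sits, so no number is known for it. Within the data shown here, the single measured step, a 1.8-fold lower number from compound 1 to compound 2 (0.25 log units; within the scatter), lies within the scatter and concerns a different change. Compound 4 `CC(C)c1c(OC2CCCCC2C)cc(CCc2ccccc2)[nH]c1=O` differs from compound 3 by isopropyl in place of iodo on an aromatic carbon. Among the measured compounds shown here, no measured step bears on this change, so its size in this assay cannot be read from the data; compounds 1 and 2, which also carry an isopropyl group, give numbers rather than limits. Compound 4 is therefore estimated at 150000 nM, between 60000 nM and 400000 nM. That estimate means an expected step of an at least 2.0-fold lower number from compound 3 to compound 4 (0.30 log units; that floor lies within the scatter).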

Compound 4, half-maximal cytotoxic concentration: 114000 nM
For compound 4 the middle estimate is 1.3-fold (0.12 log units) above the measured one, within the range that was stated.
By their numbers in this assay, from the lowest: compounds 2, 4 and 1 (each within the scatter of the next). At a limit, above all of these: compound 3.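

In this assay, among these compounds, isopropyl in place of iodo on this aromatic carbon gives the first step here that lies beyond the scatter: an at least 2.6-fold lower number from compound 3 to compound 4 (0.42 log units; beyond the scatter). That step is only a floor, since compound 3 stands at a limit and not at a number: the limit of > 300000 nM in this assay, at which 1 of the 4 values shown sits. Benzyl in place of either substituted phenyl group on the chain carbon stays within the scatter, with a 1.5-fold higher number from compound 2 to compound 4 (0.18 log units; within the scatter) and a 1.2-fold lower number from compound 1 to compound 4 (0.06 log units; within the scatter).

The compounds shown leave open how an amine, a carboxylic acid or a longer chain would fare at the position held by iodo or isopropyl. They also leave open where compound 3 itself truly lies.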